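Swapping the Sulfonamide Heteroaryl on a Shared Core

The source may report more compounds than this note shows. Statements on the series, on what has been measured and on what is new or still open speak of the compounds shown alone.

Three measured compounds share one core and differ only in the heteroaryl group on the sulfonamide nitrogen. Compound 1 `C=C1CC[C@@H]2[C@](C)(COC(C)=O)[C@H](OC(C)=O)CC[C@@]2(C)[C@H]1CC(Nc1ccc(S(=O)(=O)Nc2cc(C)on2)cc1)C1=CCOC1=O` carries a 5-methyl-1,2-oxazol-3-yl group; in a functional assay on NCI-H322M cells (Homo sapiens) for inhibition, read by sulforhodamine B assay, with a stated time of 48 h (on this read-out higher numbers stand for lower toxicity in this test and lower numbers for higher toxicity in this test), compound 1 gives 44600 nM. Compound 2 `C=C1CC[C@@H]2[C@](C)(COC(C)=O)[C@H](OC(C)=O)CC[C@@]2(C)[C@H]1CC(Nc1ccc(S(=O)(=O)Nc2nccc(C)n2)cc1)C1=CCOC1=O` gives 50700 nM, and compound 3 `C=C1CC[C@@H]2[C@](C)(COC(C)=O)[C@H](OC(C)=O)CC[C@@]2(C)[C@H]1CC(Nc1ccc(S(=O)(=O)Nc2ncccn2)cc1)C1=CCOC1=O` gives 35600 nM. Compound 1 stands second highest of the three numbers, yet every step among them stays within the scatter: a 1.1-fold higher number from compound 1 to compound 2 (0.06 log units; within the scatter), a 1.3-fold lower number from compound 1 to compound 3 (0.10 log units; within the scatter), and a 1.4-fold lower number from compound 2 to compound 3 (0.15 log units; within the scatter).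

Compound 4 `C=C1CC[C@@H]2[C@](C)(COC(C)=O)[C@H](OC(C)=O)CC[C@@]2(C)[C@H]1CC(Nc1ccc(S(=O)(=O)Nc2nccs2)cc1)C1=CCOC1=O` has not yet been measured. Relative to compound 1, (1,3-thiazol-2-yl in place of 5-methyl-1,2-oxazol-3-yl on a sulfonamide nitrogen). All three measured steps bear on this change, since each also exchanges the heteroaryl on the sulfonamide nitrogen, and none of them reached beyond the scatter. Because a 1.1-fold higher number from compound 1 to compound 2 (0.06 log units; within the scatter) and a 1.3-fold lower number from compound 1 to compound 3 (0.10 log units; within the scatter) were both within the scatter, no step beyond the scatter is expected for compound 4 in this assay, the expected step being a 1.0-fold lower number from compound 1 to compound 4 (0.01 log units; within the scatter). The estimate for compound 4 is 44000 nM, with a range from 22000 nM to 88000 nM.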

Compound 4, concentration lethal to 50% of the cells: 51600 nM
The estimate for compound 4 lay 1.2-fold (0.07 log units) below the measured number, and the stated range covers the measured number.
By their numbers in this assay, from the lowest: compounds 3, 1, 2 and 4 (each within the scatter of the next).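

With 1,3-thiazol-2-yl on the sulfonamide nitrogen, this assay shows a 1.2-fold higher number from compound 1 to compound 4 (0.06 log units; within the scatter), a 1.4-fold higher number from compound 3 to compound 4 (0.16 log units; within the scatter) and a 1.0-fold higher number from compound 2 to compound 4 (0.01 log units; within the scatter). This extends the flat picture from the oxazole and pyrimidine groups to a sulfur-bearing five-membered ring that has no methyl group, so all four heteroaryl groups at this place now stand within the scatter of one another. Nothing available here accounts for this lack of separation.

Still open, on these data alone, is whether the number would move beyond the scatter with a plain hydrogen on the sulfonamide nitrogen, or with a non-aromatic group there such as an acetyl or a short alkyl chain. As far as these compounds go, it is also open whether a phenyl ring or a larger fused heteroaryl at this place would stay within the same narrow band.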